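The compounds below may be only part of what the source reports. "The series", "measured", "known", "first", "only" and "open" are said of these compounds alone.

Measured so far in a functional assay on A549 cells (Homo sapiens) for inhibition, read by sulforhodamine B assay; on this read-out lower numbers stand for stronger inhibition of growth and higher numbers for weaker inhibition of growth:

- compound 1 `Cc1ccc2[nH]c(-c3ccc(-c4ccc(-c5ccc(N(C)C)cc5)cc4)cc3)nc2c1`: 3510 nM
- compound 2 `Fc1ccc(-c2ccc(-c3ccc(-c4nc5ccccc5[nH]4)cc3)cc2)cc1`: 33200 nM

Of these two, compound 2 has the higher number, 33200 nM, and the gap down to compound 1, at 3510 nM, lies beyond the scatter. These two compounds differ in more than one place, so their gap cannot be tied to any single change.

Not yet measured is compound 3 `Oc1ccc(-c2ccc(-c3ccc(-c4nc5ccccc5[nH]4)cc3)cc2)cc1`, which departs from compound 2 in one place: hydroxy in place of fluoro on an aromatic carbon. In words, this is hydroxy in place of fluoro on an aromatic carbon, the same difference reading 4-fluorophenyl to 4-hydroxyphenyl.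

Among the compounds with values here, no measured pair shows this change, so the expectation is loose. With compound 2 at 33200 nM, the higher of the two numbers, a moderate move towards a lower number in this assay is expected, although a step within the scatter remains possible.

The estimated change is a 2.4-fold lower number from compound 2 to compound 3 (0.38 log units; beyond the scatter).

For compound 3 the expected value is 14000 nM, with an estimated range of 4000 nM to 45000 nM.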

Compound 3, concentration for 50% growth inhibition: 33100 nM
For compound 3 the middle estimate is 2.4-fold (0.37 log units) below the measured one, within the range that was stated.
By their numbers in this assay, from the lowest: compound 1; then compounds 3 and 2 (each within the scatter of the next).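

Hydroxy in place of fluoro on an aromatic carbon, para to a large group, gives in this assay a 1.0-fold lower number from compound 2 to compound 3 (0.00 log units; within the scatter). Within the data shown here, this is the first step that can be tied to a single change, which the gap between the two earlier compounds could not be. Here, the entry of one hydrogen-bond donor and one hydrogen-bond acceptor at this position leaves the two compounds unseparated on this read-out, and nothing at hand bears on why the two groups read alike.

The compounds shown leave open whether this position accepts other groups equally, such as a methoxy group, a carboxylic acid or a longer chain, since fluoro and hydroxy are the only two groups compared there. Among these compounds, what separates compound 1 from the other two also stays unassigned, as it differs from each of them in more than one place and no single-place step connects it to either.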